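Swapping a Trifluoromethyl for Two Fluorines

The compounds below may be only part of what the source reports. "The series", "measured", "known", "first", "only" and "open" are said of these compounds alone.

Compound 2 `CN(C(=O)NC(=O)c1ccc(C(F)(F)F)cc1)c1nc(C(F)(F)F)c(C(=O)N/N=C/c2cccc(C(F)(F)F)c2)s1` carries a 4-(trifluoromethyl)phenyl on a carbonyl carbon of the shared core. Among the measured compounds shown here, in an ADME assay on L02 cells (Homo sapiens) for inhibition, read by MTT assay, with a stated time of 72 h (a higher number here means a weaker inhibitor, a lower number a stronger inhibitor), compound 2 gives 18 ug/mL, the only number available here, since for compound 1 `CN(C(=O)NC(=O)c1ccc(Cl)cc1Cl)c1nc(C(F)(F)F)c(C(=O)N/N=C/c2cccc(C(F)(F)F)c2)s1` the result in this assay is "not determined" (no result reported). Compound 3 `CN(C(=O)NC(=O)c1ccc(F)c(F)c1)c1nc(C(F)(F)F)c(C(=O)N/N=C/c2cccc(C(F)(F)F)c2)s1` differs from compound 2 in a single place: 3,4-difluorophenyl in place of 4-(trifluoromethyl)phenyl on a carbonyl carbon. For the measured compounds named here, no measured step of this kind exists to lean on, so the step of a 1.1-fold higher number from compound 2 to compound 3 (0.05 log units; within the scatter) is expected to be small, with no clear direction beyond the scatter. Compound 3 is therefore estimated at 20 ug/mL in this assay, within 8 ug/mL to 50 ug/mL.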

Compound 3, half-maximal inhibitory concentration: 23.5 ug/mL
Compound 3: the middle estimate sits 1.2-fold (0.07 log units) below what was measured; the measured number falls inside the stated range.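

In this assay this position now has a first readable step, a 1.3-fold higher number from compound 2 to compound 3 (0.12 log units; within the scatter), so on this carbonyl carbon 3,4-difluorophenyl and 4-(trifluoromethyl)phenyl cannot be told apart. Two differently fluorinated phenyl rings are therefore tolerated alike here, at least for this pair. Nothing available explains this match.

Still open, on these data alone, is whether a group of another kind on this carbonyl carbon, such as a phenyl carrying an amine or a carboxylic acid, would move the number beyond the scatter.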